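The compounds below may be only part of what the source reports. "The series", "measured", "known", "first", "only" and "open" are said of these compounds alone.

In a physicochemical assay for solubility, with a stated time of 3 days, at pH 7 (on this read-out lower numbers stand for lower solubility and higher numbers for higher solubility), compound 2 `NC(=O)c1ccc2[nH]c(-c3ccc(OCCC4CCCCN4Cc4ccccc4)cc3)nc2c1` gives 155000 nM, the higher of the two numbers available, while compound 3 `NC(=O)c1ccc2[nH]c(-c3ccc(OCCC4CCN(C(=O)c5ccccc5)CC4)cc3)nc2c1` gives 3000 nM, a gap beyond the usual scatter. For compound 1 `NC(=O)c1ccc2[nH]c(-c3ccc(OCC4CCCN(Cc5ccc(Cl)c(Cl)c5)C4)cc3)nc2c1` the result is "not determined" (no result reported). Compound 4 `CC(=O)N1CCCCC1CCOc1ccc(-c2nc3cc(C(N)=O)ccc3[nH]2)cc1` differs from compound 2 by having acetyl in place of benzyl on an amine nitrogen in a ring. Within the data shown here, no measured pair shows this change, so any expectation remains loose. Compound 3, at 3000 nM, also carries a carbonyl, which suggests a lower number than that of compound 2. A drop beyond the scatter is expected, estimated as a 5.2-fold lower number from compound 2 to compound 4 (0.71 log units; beyond the scatter). Compound 4 is estimated at 30000 nM, within an expected range of 6000 nM to 150000 nM.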

Compound 4, solubility: 193000 nM
Estimate against measurement, compound 4: 6.4-fold (0.81 log units) below; the measured number lies above the stated range.
By their numbers in this assay, from the lowest: compound 3; then compounds 2 and 4 (each within the scatter of the next).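

In this assay the step of a 1.2-fold higher number from compound 2 to compound 4 (0.10 log units; within the scatter) is within the usual scatter, so on an amine nitrogen in a ring this read-out does not separate acetyl from benzyl. This holds although the change removes a six-membered aromatic ring of carbon only and brings in a hydrogen-bond acceptor. Nothing measured here accounts for this result. As far as these compounds go, what stays open is how a free amine, a methyl group or a longer acyl chain on this nitrogen would read, and whether the same change reads alike on other rings.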